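The source may report more compounds than this note shows. Statements on the series, on what has been measured and on what is new or still open speak of the compounds shown alone.

Within the series sharing one core, compound 1 `COc1cc(C)cc(-c2c(-c3ccnc(-c4ccc(C(C)=O)cc4)c3)cnn2CC#N)c1` sits at the weaker end of the two numbers in hand: in a functional assay on ACHN cells (Homo sapiens) for inhibition, read by sulforhodamine B assay, with a stated time of 48 h (a lower number here means a stronger inhibitor of growth, a higher number a weaker inhibitor of growth), compound 1 gives 3760 nM, while compound 2 `COc1cc(C)cc(-c2nn(CC#N)cc2-c2ccnc(-c3ccc(N(C)C)cc3)c2)c1` gives 499 nM in this assay, a gap beyond the scatter. Compound 3 `COc1cc(C)cc(-c2c(-c3ccnc(-c4ccc(N(C)C)cc4)c3)cnn2CC#N)c1` is compound 1 with dimethylamino in place of acetyl on an aromatic carbon. Among the compounds with values here, no measured pair isolates this change, so the step is expected by analogy only; with a dimethylamino-bearing compound 2 at 499 nM, a move toward lower numbers is expected from compound 1 to compound 3, about a 4.7-fold lower number from compound 1 to compound 3 (0.67 log units; beyond the scatter) in this assay. Compound 3 is estimated at 800 nM, within 300 nM to 2500 nM.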

Compound 3, concentration for 50% growth inhibition: 68 nM
Compound 3: middle estimate off by 12-fold (1.07 log units), on the high side, and the stated range ends above it.
By their numbers in this assay, from the lowest: compound 3; then compound 2; then compound 1.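

In this assay, within the data shown here, this position on the shared core proves highly sensitive: going from 4-acetylphenyl to 4-(dimethylamino)phenyl gives a 55-fold lower number from compound 1 to compound 3 (1.74 log units; beyond the scatter), the first change read at a single place. Acetyl and dimethylamino match in heavy atoms and hydrogen-bond acceptors, so those counts do not separate them. Still open, as far as these compounds go, is how a primary amine, morpholine or a carboxylic acid would read at this carbon, and whether the same swap carries over to other cores. No measured evidence bears on what lies behind this step.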